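Moving away from 4-acetylphenyl in the series

The compounds below may be only part of what the source reports. "The series", "measured", "known", "first", "only" and "open" are said of these compounds alone.

In a functional assay on B16-F0 cells (Mus musculus) for inhibition, read by CCK-8 assay, with a stated time of 48 h (on this read-out lower numbers stand for stronger inhibition and higher numbers for weaker inhibition), three compounds sharing one core have been measured: compound 1 `COc1cc(-c2ccnc3cc(-c4ccc(C(F)(F)F)cc4)nn23)cc(OC)c1OC` gives 1770 nM, compound 2 `COc1cc(-c2ccnc3cc(-c4ccc(N(C)C)cc4)nn23)cc(OC)c1OC` gives 702 nM, and compound 3 `COc1cc(-c2ccnc3cc(-c4ccc(C(C)=O)cc4)nn23)cc(OC)c1OC` gives 3930 nM, the highest of the three numbers and so the weakest inhibitor of the set. Next comes compound 4 `COc1ccc(-c2cc3nccc(-c4cc(OC)c(OC)c(OC)c4)n3n2)cc1F`, with this change: 3-fluoro-4-methoxyphenyl in place of 4-acetylphenyl on an aromatic carbon. Two measured steps end on the acetyl group: a 2.2-fold higher number from compound 1 to compound 3 (0.35 log units; beyond the scatter) and a 5.6-fold higher number from compound 2 to compound 3 (0.75 log units; beyond the scatter). Read in reverse, both replacements of acetyl gave a lower number, and both steps are modest. The two replacements also differ from each other: a 2.5-fold lower number from compound 1 to compound 2 (0.40 log units; beyond the scatter). Among the measured compounds shown here, no measured compound carries the 3-fluoro-4-methoxyphenyl group, so the forecast rests on these steps alone. A modest step towards a lower number, within the span of those two steps, is therefore expected. The expected step is a 3.9-fold lower number from compound 3 to compound 4 (0.59 log units; beyond the scatter). For compound 4 the estimated value is 1000 nM, with an expected range from 350 nM to 3000 nM.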

Compound 4, half-maximal inhibitory concentration: 3950 nM
For compound 4 the middle estimate is 4.0-fold (0.60 log units) below the measured one; measured number above the stated range.
By their numbers in this assay, from the lowest: compound 2; then compound 1; then compounds 3 and 4 (each within the scatter of the next).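

In this assay the exchange of groups gives a 1.0-fold higher number from compound 3 to compound 4 (0.00 log units; within the scatter) and so shows that leaving 4-acetylphenyl at this position does not in itself bring a lower number, which the two earlier replacements could not show. The same group stands apart from both other replacements, with a 5.6-fold higher number from compound 2 to compound 4 (0.75 log units; beyond the scatter) and with a 2.2-fold higher number from compound 1 to compound 4 (0.35 log units; beyond the scatter) on the same read-out, so compound 2 stays the strongest inhibitor of the four. No measured evidence here explains these differences.

Open, going by these compounds, is how much of the standing of compound 2 belongs to the dimethylamino group itself, which a 4-aminophenyl or 4-morpholinophenyl group at this position would test. Also open, on these data alone, is how the 3-fluoro and 4-methoxy parts read singly, as 3-fluorophenyl and 4-methoxyphenyl.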